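Taking the methyl off compound 2

This account rests on a few compounds, and the source may have more. Where it says the series, first, only, none or still open, it means among the compounds named here.

Among the measured compounds shown here, in a functional assay on SK-OV-3 cells (Homo sapiens) for cytotoxicity (on this read-out lower numbers stand for stronger inhibition of growth and higher numbers for weaker inhibition of growth), compound 2 `CSc1ccc(C2=C(c3ccc(F)c(C)c3)C(=O)N3CCCC3C2)cc1` gives 300 nM, the only true number so far. Compound 1 `COc1ccc(C2=C(c3ccc(SC)cc3)CC3CCCN3C2=O)cc1O` reads > 100000 nM, which is a limit of the assay. Compound 3 `CSc1ccc(C2=C(c3ccc(F)cc3)C(=O)N3CCCC3C2)cc1` has hydrogen in place of methyl on an aromatic carbon, turning 4-fluoro-3-methylphenyl into 4-fluorophenyl. For the measured compounds named here, the one measured step, an at least 330-fold lower number from compound 1 to compound 2 (2.52 log units; beyond the scatter), is large, but it exchanged 3-hydroxy-4-methoxyphenyl for 4-fluoro-3-methylphenyl, a much bigger change than this one, so it sets no size here. In this assay the expected step is a 1.3-fold higher number from compound 2 to compound 3 (0.12 log units; within the scatter), with no shift beyond the scatter anticipated. Compound 3 is expected at 400 nM, with an estimated range of 100 nM to 1800 nM.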

Compound 3, concentration for 50% growth inhibition: 30000 nM
For compound 3 the middle estimate is 75-fold (1.88 log units) below the measured one; the measured number lies above the stated range.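

In this assay, a change of one heavy atom at this place, ortho to a fluoro group, is enough for a large step: a 100-fold higher number from compound 2 to compound 3 (2.00 log units; beyond the scatter). The methyl therefore matters on this ring, and the fluoro group alone does not hold the number of compound 2. The value of compound 1 is a limit, so an at least 3.3-fold lower number from compound 1 to compound 3 (0.52 log units; beyond the scatter) is only a bound: the limit of > 100000 nM in this assay, at which 1 of the 3 values shown sits.

The reason for the large step remains open. Also open, on these data alone, is whether an ethyl or a chlorine at this place, or a 3-methylphenyl without the fluoro group, would keep the number of compound 2.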